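The source may hold more compounds than are shown below. What is called first, only, known or untested is meant among the compounds shown, and "the series" means these compounds.

Of the compounds shown here, three built on related structures have been tested in a functional assay on the whole organism for antagonist activity, with Mus musculus as the target (a higher number here means that more compound is needed for the effect, a lower number that less compound is needed), and none has yet given a measured dose. Compound 3 `Cn1c(-c2ccccc2)nnc1[S+](C)[O-]` gives > 100 mg/kg, which is a limit of the assay and not a number. Compound 2 `Cn1c(-c2cccs2)nnc1[S+](C)[O-]` gives > 200 mg/kg, which is also only a limit. Compound 1 `Cn1c(-c2cccc(F)c2)nnc1S(C)(=O)=O`, which carries a methylsulfonyl group, gives > 200 mg/kg, again only a limit. Compound 3 therefore cannot be ranked against the other two.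

Compound 4 `Cn1c(-c2ccccc2)nnc1S(C)(=O)=O` differs from compound 3 in one place: a group of 4 heavy atoms (1 carbon, 2 oxygen, 1 sulfur; no ring) in place of a group of 3 heavy atoms (1 carbon, 1 oxygen, 1 sulfur; no ring), on an aromatic carbon. Going by the values given here, the methylsulfonyl group sits on an aromatic carbon, and no pair of tested compounds shows this change alone. The estimated step that the limit leaves unreadable from compound 3 to compound 4 is expected to stay within the usual scatter. The closest guide is compound 1, whose > 200 mg/kg is a limit reached with the same methylsulfonyl group, so another limit is the likely outcome. For compound 4 the expected dose is 180 mg/kg, with an estimated range from 90 mg/kg to 400 mg/kg.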

Compound 4, dose for half-maximal effect: 55 mg/kg
Compound 4: middle estimate off by 3.3-fold (0.51 log units), on the high side, outside the stated range (below it).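

Compound 4 is the first compound shown to give a measured dose in this assay, and the methylsulfonyl group in place of the group on compound 3 gives an at least 1.8-fold lower number from compound 3 to compound 4 (0.25 log units; that floor lies within the scatter), a floor that does not yet separate this change from the scatter. Compound 3 has only a limit, so the true size of that step cannot be read: the limit of > 100 mg/kg in this assay, at which 1 of the 4 values shown sits. With the methylsulfonyl group kept, hydrogen in place of fluoro on an aromatic carbon gives an at least 3.6-fold lower number from compound 1 to compound 4 (0.56 log units; beyond the scatter), a floor beyond the scatter, so the methylsulfonyl group alone does not settle the outcome.

From the compounds shown here alone, how far the true doses of the compounds held at a limit lie from that of compound 4 stays open. So does whether an amine or a longer chain at this place on the shared core would also give a measured dose.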